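The compounds below may be only part of what the source reports. "The series", "measured", "known", "first", "only" and "open" are said of these compounds alone.

Compound 1 `Clc1ccc2nc(-c3cccnc3)n(C3CC3)c2c1`: 2.2 nM
Compound 2 `Cc1cncc(-c2nc3cc(F)c(F)cc3n2C2CC2)c1C`: 0.2 nM
Compound 3 `COc1cncc(-c2nc3cc(F)c(F)cc3n2C2CC2)c1`: 0.4 nM

All three were tested in an assay on V79 cells for inhibition of cytochrome P450 11B2, mitochondrial (Homo sapiens), read by HTRF, with a stated time of 1 h; on this read-out lower numbers stand for stronger inhibition and higher numbers for weaker inhibition. Among them compound 1 gives the highest number, 2.2 nM, so it is the weakest inhibitor of the three. The nearest value is that of compound 3, at 0.4 nM, and the furthest is that of compound 2, at 0.2 nM; both gaps lie beyond the scatter. Compounds 2 and 3 differ from compound 1 in more than one place, so no single change between measured compounds can be read from these numbers.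

Compound 4 `COc1ccc2nc(-c3cccnc3)n(C3CC3)c2c1` has not yet been measured in this assay. It differs from compound 1 in one place: methoxy in place of chloro on an aromatic carbon. Going by the values given here, no measured pair shows what this particular swap does, so the expectation rests only on the value of compound 1, 2.2 nM, and on the small size of the change itself; nothing here points to a large move. The step expected in this assay is a 1.4-fold higher number from compound 1 to compound 4 (0.13 log units; within the scatter), a slight rise in the number that may well fall within the scatter. Compound 4 is therefore estimated at 3 nM, with a range from 1.2 nM to 8 nM.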

Compound 4, half-maximal inhibitory concentration: 24 nM
The estimate for compound 4 lay 8.0-fold (0.90 log units) below the measured number; measured number above the stated range.
By their numbers in this assay, from the lowest: compounds 2 and 3 (each within the scatter of the next); then compound 1; then compound 4.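

In this assay, methoxy in place of chloro on this aromatic carbon gives an 11-fold higher number from compound 1 to compound 4 (1.04 log units; beyond the scatter), a large step beyond the scatter. Going by these compounds alone, this is the first direct reading of this position, and it shows that inhibition in this assay can depend strongly on the group held here, even when the change is as small as one heavy atom leaving and two entering. No measurement shown here accounts for the size of this step, so it stands as an observation without an established cause.

A single swap cannot tell whether the loss is specific to methoxy or would follow from other replacements of chloro, and a hydroxy group, a methyl group, an ethoxy group or an amine on the same carbon would help to separate those possibilities. Within the data shown here, it also remains open whether the same swap would produce a step of similar size with different groups elsewhere on the core, as this one pair of compounds is the only reading of the change.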